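The source may hold more compounds than are shown below. What is called first, only, known or untested is meant among the compounds shown, and "the series" means these compounds.

Compound 1 `OC[C@H]1OC(n2cnc3c(Nc4ccccc4)nccc32)[C@H](O)[C@@H]1O` gives 10% in a functional assay on EL4 cells (Mus musculus) for inhibition, tested at 100 uM; on this read-out higher numbers stand for more inhibition at the one concentration tested (going by the name of the read-out) and lower numbers for less inhibition. Compound 2 `OCCNc1[nH]ccc2ncnc1-2` reaches only the assay limit of < 5% in this assay.

Among the compounds with values here, compound 1 thus carries the only number recorded; the other value is a limit, (the limit of < 5% in this assay, at which 1 of the 2 values shown sits). Compound 3 `CN(C)c1nccc2c1ncn2C1O[C@H](CO)[C@@H](O)[C@H]1O` is still unmeasured. It differs from compound 1 by dimethylamino in place of anilino on an aromatic carbon. Within the data shown here, with no step between measured compounds available, the expectation rests on compound 1 alone, and a change no larger than the usual scatter is expected, if anything tending downward. Compound 3 is therefore estimated at about 6%, between 0% and 15%, an expected step of a number 4 percentage points lower from compound 1 to compound 3 (within the scatter).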

Compound 3, a percentage reported as inhibition, at one concentration (the size of the read-out at that concentration, not a potency): 10%
Estimate against measurement, compound 3: 4 percentage points below; the range from low to high includes it.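

Dimethylamino in place of anilino, on the aromatic carbon next to the ring nitrogen, gives no change at the digits printed from compound 1 to compound 3 (within the scatter) in this assay. At this position, then, neither the six-membered aromatic ring of anilino nor its hydrogen-bond donor is needed to keep the read-out at the level of compound 1. The read-out stays low across the series, and one entry is a limit rather than a number: the limit of < 5% in this assay, at which 1 of the 3 values shown sits.

Still open, on these data alone, is whether a primary amine or a longer chain carrying a carboxylic acid at this position would move the read-out beyond the scatter.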